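Cytotoxicity of amide variants on the shared core

This account rests on a few compounds, and the source may have more. Where it says the series, first, only, none or still open, it means among the compounds named here.

Measured so far:
compound 1 `CC(C)n1ncc2c(C(=O)Nc3cc(S(N)(=O)=O)ccc3F)cc(-c3cccs3)nc21` — 25000 nM
compound 2 `CC(C)n1ncc2c(C(=O)Nc3c(F)cc(F)cc3F)cc(-c3cccs3)nc21` — > 200000 nM
compound 3 `CC(C)n1ncc2c(C(=O)Nc3ccc(F)c(F)c3)cc(-c3cccs3)nc21` — > 200000 nM

In an ADME assay on LLC-MK2 cells (Macaca mulatta) for cytotoxicity, read by spectrophotometry and crystal violet staining, with a stated time of 4 days (on this read-out lower numbers stand for higher toxicity in this test and higher numbers for lower toxicity in this test), compound 3 returns only a limit, > 200000 nM. Compound 2 likewise returns only a limit, > 200000 nM. Among the compounds with values here, compound 1 is the sole compound with a numerical value, 25000 nM. Within the data shown here, the single step between measured neighbours, a step that the two limits leave unreadable from compound 2 to compound 3, cannot be sized because both ends sit at a limit; see (the limit of > 200000 nM in this assay, at which 2 of the 3 values shown sit).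

Compound 4 `CC(C)n1ncc2c(C(=O)Nc3cc(C(N)=O)ccc3F)cc(-c3cccs3)nc21` is not yet measured. It differs from compound 3 thus: 5-carbamoyl-2-fluorophenyl in place of 3,4-difluorophenyl on an amide-type nitrogen. Among the measured compounds shown here, no measured step bears directly on this change; the only relevant comparison is compound 1, which carries a 2-fluorophenyl bearing a sulfamoyl group and sits at 25000 nM, clearly inside the measurable range. The 5-carbamoyl-2-fluorophenyl of compound 4 is expected to place it between compound 1 and the limit; the estimate for compound 4 is 80000 nM with range 20000 nM to 200000 nM, a step of an at least 2.5-fold lower number from compound 3 to compound 4 (0.39 log units; beyond the scatter) that is expected but cannot be confirmed from a limit.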

Compound 4, half-maximal cytotoxic concentration: 25000 nM
Compound 4: middle estimate off by 3.2-fold (0.51 log units), on the high side; the range from low to high includes it.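

In this assay, the 5-carbamoyl-2-fluorophenyl on the amide-type nitrogen gives the first readable steps from the fluorophenyl amides: an at least 8.0-fold lower number from compound 3 to compound 4 (0.90 log units; beyond the scatter), and an at least 8.0-fold lower number from compound 2 to compound 4 (0.90 log units; beyond the scatter). These steps give only a minimum size because compound 2 and compound 3 each return a limit: the limit of > 200000 nM in this assay, at which 2 of the 4 values shown sit. Carbamoyl in place of sulfamoyl on an aromatic carbon gives no change at the digits printed from compound 1 to compound 4 (within the scatter), so this read-out does not separate the two groups.

The compounds shown do not separate the contribution of the carbamoyl from that of the fluorine within the 5-carbamoyl-2-fluorophenyl. From the compounds shown here alone, it also remains open whether a carboxylic acid or an amine in place of the carbamoyl would give a similar number in this assay.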